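Pyridin-2-ylmethyl Amide Next in Cytotoxicity Screen

A few compounds are considered here, and "the series" means these few. Any claim that something is new, unique, unknown or untested is made for them only; others in the source may bear on it.

Measured so far:
compound 1 `Cn1c(Cc2ccccc2C(F)(F)F)nc(C(=O)NCc2cccnc2)c(O)c1=O` — > 100000 nM
compound 2 `CC(c1ccccc1C(F)(F)F)c1nc(C(=O)NCc2ccccc2)c(O)c(=O)n1C` — > 100000 nM
compound 3 `Cn1c(Cc2ccccc2C(F)(F)F)nc(C(=O)Nc2ccccc2)c(O)c1=O` — > 100000 nM

In an ADME assay on HepG2 cells (Homo sapiens) for cytotoxicity, in the presence of a further agent that is not named here (on this read-out higher numbers stand for weaker inhibition and lower numbers for stronger inhibition), compound 1 gives > 100000 nM, which is a limit of the assay and not a number. Compound 2 gives > 100000 nM in this assay, again a limit. Compound 3 gives > 100000 nM in this assay, also a limit. All three values sit at the limit of > 100000 nM in this assay, at which 3 of the 3 values shown sit, so none of them separates from another.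

Among the compounds with values here, the one step touching compound 3, a step that the two limits leave unreadable from compound 1 to compound 3, cannot be read, since both of its ends are limits. Compound 3 therefore stands at the limit with nothing to place it above or below its neighbours.

Compound 4 `Cn1c(Cc2ccccc2C(F)(F)F)nc(C(=O)NCc2ccccn2)c(O)c1=O` differs from compound 3 by (pyridin-2-yl)methyl in place of phenyl on an amide-type nitrogen. Within the data shown here, no measured step bears on this change in a readable way. What the three values do show is that a (pyridin-3-yl)methyl group, a phenyl group and a benzyl group on the amide-type nitrogen all left this assay at its limit.

Compound 4 is expected to give 100000 nM in this assay, within 50000 nM to 300000 nM. The step expected from this, a number no higher from compound 3 to compound 4 (the limit leaves the size open), is estimated to be none beyond the scatter.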

Compound 4, half-maximal inhibitory concentration: > 100000 nM
Compound 4 gave a limit, no number; the forecaster's own chance of this, stated with the estimate: 85%; the middle value lies on the limit itself.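

In this assay compound 4 gives > 100000 nM, a limit of the assay and not a number. The steps to compound 4 from compound 1 and compound 3 therefore cannot be read, since each has a limit at both ends: the limit of > 100000 nM in this assay, at which 4 of the 4 values shown sit.

The compounds shown leave open whether any group on the amide-type nitrogen would give a number rather than a limit in this assay.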